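This account rests on a few compounds, and the source may have more. Where it says the series, first, only, none or still open, it means among the compounds named here.

Working notes on a small set of fused-ring analogues read in a functional assay on HeLa cells (Homo sapiens) for inhibition; on this read-out lower numbers stand for stronger inhibition and higher numbers for weaker inhibition.

Compound 1, `CC(=O)OC(C)n1cnc2c(Cl)nc(N)nc21`, returns only a limit in this assay: > 500000 nM, a limit of the assay rather than a number. Compound 2, `CC(=O)OC(C)n1cnc2c(Cl)nc(F)nc21`, carries fluoro in place of amino on an aromatic carbon relative to compound 1, and in this assay compound 2 gives 50000 nM. The step is an at least 10-fold lower number from compound 1 to compound 2 (1.00 log units; beyond the scatter); its size can be stated only as a bound because the limit of > 500000 nM in this assay, at which 1 of the 3 values shown sits, sets the starting point.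

Compound 3, `CC(=O)OCCOn1cnc2c(S)nc(N)nc21`, sits on a different core; how the core of compound 3 differs from that of compound 1 is not broken down here. In this assay compound 3 gives 5000 nM, the lowest number among the two numbers measured, and a lower number than compound 2.

Compound 4, `CC(=O)OCCOn1cnc2c(S)nc(F)nc21`, is not yet measured. It carries fluoro in place of amino on an aromatic carbon relative to compound 3. This is the same kind of change as seen from compound 1 to compound 2, but the surroundings differ: in the pair of compound 1 and compound 2 the place is meta to a chloro group (1 heavy atom), whereas in the pair of compound 3 and compound 4 it is meta to a sulfanyl group (1 heavy atom).

The expected step is a 7.1-fold lower number from compound 3 to compound 4 (0.85 log units; beyond the scatter), which rests on an at least 10-fold lower number from compound 1 to compound 2 (1.00 log units; beyond the scatter) and is taken as modest since that step is only a bound. Compound 4 is expected near 700 nM, between 150 nM and 3000 nM.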

Compound 4, half-maximal inhibitory concentration: > 500000 nM
Compound 4: no number, only a limit (the forecaster's own chance of this, stated with the estimate: 5%); middle value at least 710-fold (2.85 log units) away from the limit.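

In this assay, fluoro in place of amino on an aromatic carbon gives an at least 100-fold higher number from compound 3 to compound 4 (2.00 log units; beyond the scatter), so the direction of this change does not carry over from the core of compound 1 to the core of compound 3, and the two steps run opposite ways: the same change on two cores in this assay, an at least 10-fold lower number (1.00 log units; beyond the scatter) from compound 1 to compound 2 and an at least 100-fold higher number (2.00 log units; beyond the scatter) from compound 3 to compound 4, at least 1000-fold (3.00 log units) apart, beyond the scatter of two such steps

Neither step has an exact size, as each has one end at a limit of the assay rather than at a number, so the sizes are bounds only and the true gap between the two steps stays unfixed: the limit of > 500000 nM in this assay, at which 2 of the 4 values shown sit.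

Two cores show that the outcome of this change depends on its surroundings in this series, but they do not show which part of a core decides the direction, nor which direction a third core would take.

The compounds shown leave open whether the reversal goes with the sulfanyl group, with the chloro group or with the chain on the rest of the core, as no pair here isolates any one of these. Also open, on these data alone, is how a methylamino or a methoxy group in the place of amino or fluoro would read on either core, which would show whether the result is particular to these two groups.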